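Methoxy to (pyridin-2-yl)oxy: expected maximal response

The source may hold more compounds than are shown below. What is called first, only, known or untested is meant among the compounds shown, and "the series" means these compounds.

Compound 1 `COc1ccc(-c2ccn(CCC(C)C)c(=O)c2C#N)cc1` is the reference point of this comparison. In a functional assay on CHO cells for positive allosteric modulation of metabotropic glutamate receptor 2 (Homo sapiens), read by scintillation counting and GTPgammaS binding, with a stated time of 30 min (on this read-out higher numbers stand for larger maximal responses and lower numbers for smaller maximal responses), compound 1 gives 160%. Compound 2 `COc1ccc(-c2ccn(CCC(C)C)c(=O)c2C#N)cc1F` gives 160% in this assay, and compound 3 `COc1ccc(-c2ccn(CCC(C)C)c(=O)c2C#N)cc1Cl` gives 200% in this assay. Compound 1 therefore stands level with compound 2, the two together at the lowest of the three numbers; the step of no change at the digits printed from compound 1 to compound 2 (within the scatter) stays within the scatter, whereas a number 40 percentage points higher from compound 1 to compound 3 (beyond the scatter) and a number 40 percentage points higher from compound 2 to compound 3 (beyond the scatter) lie beyond it.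

Compound 4 `CC(C)CCn1ccc(-c2ccc(Oc3ccccn3)cc2)c(C#N)c1=O` differs from compound 1 in another place: pyridin-2-yl in place of methyl on an oxygen on an aromatic ring. All three measured steps concern a halogen in place of hydrogen, or chloro in place of fluoro, on an aromatic carbon; none touches the substituent on the oxygen, so none bears directly on this change. Resting only on compound 1 at 160%, the expected step in this assay is no change at the digits printed from compound 1 to compound 4 (within the scatter), that is, nothing beyond the scatter, with wide uncertainty. Compound 4 is accordingly estimated at 160% in this assay, within a range of 115% to 205%.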

Compound 4, largest response reached (Emax), in percent of the reference or control that the assay uses: 249%
Estimate against measurement, compound 4: 89 percentage points below, outside the stated range (above it).
By their numbers in this assay, from the lowest: compounds 1 and 2 (each within the scatter of the next); then compound 3; then compound 4.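

The oxygen on the aromatic ring proves to be a place where the maximal response can move in this assay, with pyridin-2-yl in place of methyl giving a number 89 percentage points higher from compound 1 to compound 4 (beyond the scatter). Going by these compounds alone, the earlier steps covered only changes on an aromatic carbon, so this is the first sign that the group on this oxygen also matters for the response, and that an aromatic ring is tolerated here with no loss of response. Nothing on hand explains the rise.

As far as these compounds go, whether the step comes from the ring as such or from its nitrogen stays open; phenyl or pyridin-3-yl on the same oxygen would separate the two. Also open, from the compounds shown here alone, is whether chloro on the aromatic carbon and pyridin-2-yl on the oxygen would add up in one compound.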